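The source may report more compounds than this note shows. Statements on the series, on what has been measured and on what is new or still open speak of the compounds shown alone.

Measured in an ADME assay on microsomes from liver (Homo sapiens) for metabolic stability, with a stated time of 10 min; a higher number here means that more of the compound is left, a lower number that less of the compound is left:
- compound 1 `CC[C@]1(C(=O)O)CC[C@H](C(=O)N2CC[C@](c3ccc(C(F)(C(F)(F)F)C(F)(F)F)cc3)(S(=O)(=O)c3ccc(F)cc3)C2)CC1`: 100%
- compound 2 `O=C(O)C1CCC(O)(C(=O)N2CC[C@](c3ccc(C(F)(C(F)(F)F)C(F)(F)F)cc3)(S(=O)(=O)c3ccc(F)cc3)C2)CC1`: 100%; 95% (2 entries)
- compound 3 `O=C(O)C12CCC(C(=O)N3CC[C@](c4ccc(C(F)(C(F)(F)F)C(F)(F)F)cc4)(S(=O)(=O)c4ccc(F)cc4)C3)(CC1)CC2`: 100%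

On these numbers, compound 3 gives 100% in this assay, level with compound 1. Compound 4 `O=C(O)C12CCC(C(=O)N3CC[C@](c4ccc(C(F)(C(F)(F)F)C(F)(F)F)cc4)(S(=O)(=O)c4ccc(F)cc4)C3)(CC1)OC2` is not yet measured. It differs from compound 3 in one place, on a carbonyl carbon whose other neighbours are: amide-type nitrogen in a ring. The change is a group of 11 heavy atoms (8 carbon, 3 oxygen; one six-membered non-aromatic ring of carbon only, one six-membered non-aromatic ring with 1 hetero atom) in place of a group of 11 heavy atoms (9 carbon, 2 oxygen; 2 six-membered non-aromatic rings of carbon only), on a carbonyl carbon. One six-membered non-aromatic ring of carbon only thus gives way to a six-membered non-aromatic ring with 1 hetero atom.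

The closest measured evidence is no change at the digits printed from compound 1 to compound 3 (within the scatter), a swap of a group at this same place that moved nothing beyond the scatter. Repeat readings also give a sense of how closely results agree, as seen in the several entries of compound 2 in this assay, 100%; 95% (2 entries). For the measured compounds named here, no measured step brings a hetero atom into this ring, so the expectation remains tentative. On this evidence, no step beyond the scatter is expected, and the expected change is a number 3 percentage points lower from compound 3 to compound 4 (within the scatter). For compound 4 the estimated value is 97%, with an expected range of 85% to 100%.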

Compound 4, percent of the compound remaining: 90%
Compound 4: middle estimate off by 7 percentage points, on the high side; measured number inside the range.
By their numbers in this assay, from the lowest: compounds 4, 1 and 3 (each within the scatter of the next).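

The first hetero atom at this place, a ring oxygen in the group on the carbonyl carbon, gives in this assay a number 10 percentage points lower from compound 3 to compound 4 (within the scatter). Set against the group with one carbon ring, the same compound gives a number 10 percentage points lower from compound 1 to compound 4 (within the scatter), so at this place, both swaps stay within the scatter and neither shows a real change in the amount of compound left. Repeat readings give a measure of how closely results for a single compound agree: the several entries of compound 2 in this assay, 100%; 95% (2 entries).

The compounds shown leave open whether a hetero atom other than oxygen, such as an amine nitrogen or a sulfur atom in the same ring, would also stay within the scatter. They also leave open whether compound 3 and compound 4 would separate after a longer time with the microsomes.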